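The compounds below may be only part of what the source reports. "The series", "measured", "known", "first", "only" and "open" are said of these compounds alone.

In an ADME assay on L1210 cells (Mus musculus) for cytotoxicity, with a stated time of 48 h (a lower number here means a stronger inhibitor, a higher number a weaker inhibitor), compound 2 `C=C1[C@H](C)CCC[C@]1(C)CC/C(C)=C/CC1=C(O)C(=O)C=C(OC)C1=O` gives 2.4 ug/mL, the lowest of the two numbers shown. Compound 3 `CC1=CCC[C@H]2[C@](C)(CC3=C(O)C(=O)C=C(N[C@@H](CO)C(=O)O)C3=O)[C@@H](C)CC[C@]12C` gives 3.8 ug/mL, which sits within the scatter of compound 2. Compound 1 `C=C1[C@H](C)CCC[C@]1(C)CC/C(C)=C/CC1=C(O)C(=O)C=C(N[C@@H](CO)C(=O)O)C1=O` reaches only the limit of the assay at > 10 ug/mL. Compound 4 `C=C1[C@H](C)CCC[C@]1(C)CC/C(C)=C/CC1=C(O)C(=O)C=C(N[C@H](C(=O)O)C(C)C)C1=O` has not yet been measured; it carries (1-carboxy-2-methylpropyl)amino in place of methoxy on a double-bonded ring carbon. Among the compounds with values here, the only measured step bearing on this is an at least 4.1-fold lower number from compound 1 to compound 2 (0.61 log units; beyond the scatter), which runs opposite to the change now made, and the limit of > 10 ug/mL in this assay, at which 1 of the 3 values shown sits, leaves its size known only as a floor. Returning to a carboxy-bearing amino group is therefore expected to raise the number, by about a 3.3-fold higher number from compound 2 to compound 4 (0.52 log units; beyond the scatter). Compound 4 is estimated at 8 ug/mL, with a likely range from 3 ug/mL to 20 ug/mL.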

Compound 4, half-maximal inhibitory concentration: 4.4 ug/mL
The estimate for compound 4 lay 1.8-fold (0.26 log units) above the measured number, within the range that was stated.
By their numbers in this assay, from the lowest: compounds 2, 3 and 4 (each within the scatter of the next). At a limit, above all of these: compound 1.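

A carboxy-bearing amino group on this double-bonded ring carbon does not by itself raise the number in this assay: the change from methoxy gives a 1.8-fold higher number from compound 2 to compound 4 (0.26 log units; within the scatter). What is attached to the chain carbon bound to the amine nitrogen matters, since isopropyl in place of hydroxymethyl gives an at least 2.2-fold lower number from compound 1 to compound 4 (0.35 log units; beyond the scatter). Compound 1 stands at a limit, so the size of that step is only a floor: the limit of > 10 ug/mL in this assay, at which 1 of the 4 values shown sits.

Going by these compounds, whether a simple amine without the carboxylic acid would behave the same at this position remains open. So does the effect of a longer chain in place of isopropyl.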